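A few compounds are considered here, and "the series" means these few. Any claim that something is new, unique, unknown or untested is made for them only; others in the source may bear on it.

Measured in a functional assay on A549 cells (Homo sapiens) for antiproliferative activity, read by MTT assay, with a stated time of 48 h; on this read-out lower numbers stand for stronger inhibition and higher numbers for weaker inhibition:
Compound 1 `CC(C)=CCC[C@]1(C)/C=C/[C@@H](OC(=O)C=C(C)C)[C@](C)(O)CCC(=O)/C(CO)=C\C1`: > 40000 nM (a limit)
Compound 2 `CC(C)=CCC[C@]1(C)/C=C/[C@@H](OC(=O)C=C(C)C)[C@](C)(O)/C=C/[C@H](O)/C(CO)=C\C1`: > 40000 nM (a limit)
Compound 3 `CC(C)=CCC[C@](C)(/C=C/[C@@H](OC(=O)C=C(C)C)[C@](C)(O)/C=C/C(=O)/C=C/N(C)C)CC=O`: 11200 nM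

Compound 2 gives no number, only a limit, and so it stands at the limit of > 40000 nM in this assay, at which 2 of the 3 values shown sit. Compound 4 `CO[C@H]1/C=C/[C@@](C)(O)[C@H](OC(=O)C=C(C)C)/C=C/[C@@](C)(CCC=C(C)C)C/C=C\1CO` differs from it in one place: methyl in place of hydrogen on an oxygen on a saturated carbon, or hydroxy to methoxy. Within the data shown here, no measured pair shows this change, so nothing points to a gain in this assay, and no shift beyond the usual scatter is expected. The expected size of the change is a number no higher from compound 2 to compound 4 (the limit leaves the size open). Compound 4 is estimated at 40000 nM, with an expected range from 20000 nM to 80000 nM.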

Compound 4, half-maximal inhibitory concentration: 19200 nM
The estimate for compound 4 lay 2.1-fold (0.32 log units) above the measured number; the whole stated range lies above it.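

Hydroxy to methoxy on this saturated ring carbon gives an at least 2.0-fold lower number from compound 2 to compound 4 (0.31 log units; beyond the scatter) in this assay. This is the first step shown at this position, and it shows that the hydrogen on this oxygen is not required for a measurable number in this assay. The full size of the step stays open, because compound 2 gives only a limit: the limit of > 40000 nM in this assay, at which 2 of the 4 values shown sit.

On these data alone, whether an ethoxy group or an amine in place of the methoxy would lower the number further remains open. So does whether the same change would have a similar effect on another compound.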